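Cytotoxicity on the shared core, extended to compound 3

The source may report more compounds than this note shows. Statements on the series, on what has been measured and on what is new or still open speak of the compounds shown alone.

Readings in an ADME assay on BJ cells (Homo sapiens) for cytotoxicity, with a stated time of 72 h (on this read-out higher numbers stand for an effect only at larger amounts of compound and lower numbers for an effect already at smaller amounts), so far:
compound 1, `CCc1ccc(-c2nc3c(c(C)nn3-c3ccccc3)c(-c3ccccc3O)c2C#N)cc1`, gives > 20000 nM, which is a limit of the assay and not a number.
compound 2, `CCc1ccc(-c2nc3c(c(C)nn3-c3ccccc3)c(-c3ccccc3C(=O)O)c2C#N)cc1`, gives > 20000 nM, again a limit of the assay.

Compound 1 therefore stands only at a limit in this assay; the other value shown is a limit as well. For the measured compounds named here, the one measured step, a step that the two limits leave unreadable from compound 1 to compound 2, cannot be read, since both values sit at the limit of > 20000 nM in this assay, at which 2 of the 2 values shown sit.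

Compound 3, `Cc1nn(-c2ccccc2)c2nc(-c3ccc4c(c3)OCCO4)c(C#N)c(-c3ccccc3O)c12`, differs from compound 1 by 2,3-dihydro-1,4-benzodioxin-6-yl in place of 4-ethylphenyl on an aromatic carbon. Going by the values given here, no measured step bears readably on this change. With both known values at the limit, compound 3 is expected to remain at or near the limit in this assay, the expected step being a step that the limit leaves unreadable from compound 1 to compound 3, nothing beyond the scatter. The estimate for compound 3 is 30000 nM, with a range from 12000 nM to 90000 nM.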

Compound 3, half-maximal effective concentration: > 20000 nM
Compound 3 was reported as a limit; the forecaster's own chance of this, stated with the estimate: 80%; the middle value does not contradict the limit.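

No new step can be read: compound 1 and compound 3 stand only at limits in this assay, so 2,3-dihydro-1,4-benzodioxin-6-yl in place of 4-ethylphenyl stays unreadable: the limit of > 20000 nM in this assay, at which 3 of the 3 values shown sit.

The compounds shown leave open at what concentration, if any, compounds on the shared core act in this assay.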